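Aryl swap on the shared core and microsomal clearance

The compounds below may be only part of what the source reports. "The series", "measured", "known", "first", "only" and "open" are said of these compounds alone.

Compound 3 `Cc1cc(C)c(-c2cccnc2)cc1NC(=O)c1ccc(OCc2ccccn2)cc1` stands second highest of the three numbers measured in an ADME assay on microsomes from liver (Homo sapiens) for metabolic stability (on this read-out higher numbers stand for fast clearance and lower numbers for slow clearance), where compound 3 gives 62 mL.min-1.g-1. Compound 1 `Cc1csc(-c2cc(NC(=O)c3ccc(OCc4ccccn4)cc3)c(C)cc2C)n1` gives 513 mL.min-1.g-1 and compound 2 `Cc1cc(C)c(-c2c[nH]nc2C)cc1NC(=O)c1ccc(OCc2ccccn2)cc1` gives 20 mL.min-1.g-1. Compound 4 `Cc1cc(C)c(-c2ccc(N)cn2)cc1NC(=O)c1ccc(OCc2ccccn2)cc1` differs from compound 3 by 5-aminopyridin-2-yl in place of pyridin-3-yl on an aromatic carbon. Among the measured compounds shown here, the steps that bear on this change are an 8.3-fold lower number from compound 1 to compound 3 (0.92 log units; beyond the scatter) and a 3.1-fold higher number from compound 2 to compound 3 (0.49 log units; beyond the scatter), both modest; the larger step of a 26-fold lower number from compound 1 to compound 2 (1.41 log units; beyond the scatter) shows the widest span seen in this assay. Because the aryl swaps seen so far moved this assay by a 3.1-fold higher number from compound 2 to compound 3 (0.49 log units; beyond the scatter) at the smaller end, compound 4 is expected to sit near compound 3 or somewhat lower, a step of a 1.8-fold lower number from compound 3 to compound 4 (0.25 log units; within the scatter). Compound 4 is estimated at 35 mL.min-1.g-1, with a range of 12 mL.min-1.g-1 to 100 mL.min-1.g-1.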

Compound 4, intrinsic clearance in microsomes: 9 mL.min-1.g-1
Beside the measured number, compound 4's estimate is 3.9-fold (0.59 log units) above it; measured number outside the range, below it.
By their numbers in this assay, from the lowest: compound 4; then compound 2; then compound 3; then compound 1.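

Among the compounds shown here, the 5-aminopyridin-2-yl group gives the lowest number so far in this assay (a 6.9-fold lower number from compound 3 to compound 4 (0.84 log units; beyond the scatter)), and it also falls under the earlier low point (a 2.2-fold lower number from compound 2 to compound 4 (0.35 log units; beyond the scatter)), widening the span across this position (a 57-fold lower number from compound 1 to compound 4 (1.76 log units; beyond the scatter)). Two groups that each carry one six-membered aromatic ring with 1 hetero atom therefore differ beyond the scatter, so ring type alone does not set the number here. Nothing measured here accounts for this drop.

Compound 4 differs from compound 3 both in the amine and in where the ring nitrogen and the bond to the core lie, and these two changes remain unseparated. A plain pyridin-2-yl, or a methoxy group in place of the amine, would pull them apart.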